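A few compounds are considered here, and "the series" means these few. Any claim that something is new, unique, unknown or untested is made for them only; others in the source may bear on it.

Notes on the series in a functional assay (aorta) with Oryctolagus cuniculus as the target; a higher number here means a weaker inhibitor, a lower number a stronger inhibitor.

Three compounds have a measured value. Compound 1 `OCc1ccc(-c2nn(Cc3cccc(F)c3)c3ccccc23)o1` gives 10000 nM in this assay. Compound 2 `OCc1ccnc(-c2nn(Cc3ccccc3F)c3ncccc23)n1` gives 1300 nM, the lowest of the three numbers. Compound 3 `CCCc1cnc(-c2nn(Cc3ccccc3F)c3ncccc23)nc1N` gives 252000 nM, the highest of the three; its distance to compound 1 and its larger distance to compound 2 both lie beyond the scatter of repeat measurements, so compound 3 is the weakest inhibitor of the three on these numbers.

Compound 4 `N#CCCc1cnc(-c2nn(Cc3ccccc3F)c3ncccc23)nc1N` is not yet measured. It differs from compound 3 in one place: cyano in place of methyl on a saturated chain carbon, two bonds along the chain from an aromatic carbon. The rest of the structure is the same as in compound 3.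

Going by the values given here, no pair of measured compounds in the set differs in a single place, so no measured step is available to guide the expectation for this change; the three measured compounds differ from one another in several places at once. With nothing to go on beyond the value of compound 3, the expected step from compound 3 to compound 4 is small, a 1.7-fold lower number from compound 3 to compound 4 (0.23 log units; within the scatter), leaning slightly toward a lower number but without confidence that it exceeds the scatter. Compound 4 is therefore expected to give about 150000 nM in this assay, within a range of 40000 nM to 600000 nM.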

Compound 4, half-maximal inhibitory concentration: 412000 nM
Compound 4: middle estimate off by 2.7-fold (0.44 log units), on the low side; the measured number falls inside the stated range.
By their numbers in this assay, from the lowest: compound 2; then compound 1; then compounds 3 and 4 (each within the scatter of the next).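

In this assay the series now has its first single-place step, a 1.6-fold higher number from compound 3 to compound 4 (0.21 log units; within the scatter), for cyano in place of methyl on a saturated chain carbon, two bonds along the chain from an aromatic carbon. Read the other way out, the same difference turns propyl into 2-cyanoethyl, adding two heavy atoms for one, a triple bond and a hydrogen-bond acceptor by count, and even so the two compounds cannot be told apart in this assay, so this position tolerates the exchange without a measurable separation in either direction. No measurement on hand speaks to why the two numbers sit together.

As far as these compounds go, whether this position is insensitive in general stays open, since a single pair cannot separate a flat response from two groups that merely happen to read alike, and an amine, a carboxylic acid or a longer chain at the end of this substituent would test that. Also open, from the compounds shown here alone, is whether the same exchange of methyl for cyano reads the same way on the other cores.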